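The source may hold more compounds than are shown below. What is called first, only, known or untested is meant among the compounds shown, and "the series" means these compounds.

In an ADME assay on HEK293 cells (Homo sapiens) for cytotoxicity, read by sulforhodamine B assay, with a stated time of 48 h, tested at 10 uM (on this read-out higher numbers stand for more inhibition at the one concentration tested (going by the name of the read-out) and lower numbers for less inhibition), two compounds have been measured so far:

compound 1, `CCCCCc1cn(C(c2ccccc2)c2cc3cc(Br)ccc3nc2OC)nn1`, gives -2%
compound 2, `COc1nc2ccc(Br)cc2cc1C(c1ccccc1)n1cc(-c2cccc(F)c2)nn1`, gives 6.84%

Compound 2 and compound 1 lie within the usual scatter of this kind of measurement, so on these two numbers compound 2 cannot be told apart from compound 1; both show essentially no inhibition at the single concentration tested.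

Compound 3, `COc1nc2ccc(Br)cc2cc1C(c1ccccc1)n1cc(CCCCCO)nn1`, has not yet been measured in this assay. It differs from compound 2 in one place: 5-hydroxypentyl in place of 3-fluorophenyl on an aromatic carbon. Going by the values given here, only one measured step exists for comparison, a number 8.8 percentage points higher from compound 1 to compound 2 (within the scatter), which exchanged a plain chain for the same 3-fluorophenyl that now leaves, and it stayed within the scatter. It touches the same position but a different pair of groups, so it bears only loosely on the change to compound 3.

Because compound 1 gives -2% and compound 2 gives 6.84%, both far from strong inhibition, no step beyond the scatter is expected in this assay for compound 3; the expected step is a number 3.8 percentage points lower from compound 2 to compound 3 (within the scatter). The estimate for compound 3 is 3%, in a range from -9% to 15%.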

Compound 3, a percentage reported as inhibition, at one concentration (the size of the read-out at that concentration, not a potency): 7.96%
Compound 3: middle estimate off by 5 percentage points, on the low side; low and high end bracket the measured number.
By their numbers in this assay, from the lowest: compounds 1, 2 and 3 (each within the scatter of the next).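

In this assay, the position on the five-membered aromatic ring has now carried three quite different groups: a pentyl chain, a 3-fluorophenyl ring and a 5-hydroxypentyl chain. Replacing the ring with a chain that has no ring and brings a hydrogen-bond donor and acceptor gives a number 1.1 percentage points higher from compound 2 to compound 3 (within the scatter), and hydroxy in place of hydrogen on a saturated chain carbon, five bonds along the chain from an aromatic carbon, gives a number 10 percentage points higher from compound 1 to compound 3 (within the scatter), so neither change can be told from the scatter and the three groups are not separated by this read-out. Nothing on hand offers an explanation for why these groups read alike.

Going by these compounds, it remains open whether an amine or a carboxylic acid in place of the hydroxy, or a longer chain, would give a reading that stands clear of the scatter at this position. The three compounds also share the rest of their structure, so they say nothing about how changes elsewhere on the shared core would read.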